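A few compounds are considered here, and "the series" means these few. Any claim that something is new, unique, unknown or untested is made for them only; others in the source may bear on it.

Measured so far in an assay on membranes from HeLa cells for displacement of a labelled ligand from adenosine receptor A3 (Homo sapiens), read by scintillation counting, with a stated time of 180 min, tested at 1 uM; on this read-out higher numbers stand for more inhibition at the one concentration tested (going by the name of the read-out) and lower numbers for less inhibition:
- compound 1, `CC1=C(C(=O)OCC(C)C)C(c2ccco2)NC(=O)N1C`: 23%
- compound 2, `CC1=C(C(=O)OCC(C)C)C(c2ccoc2)NC(=O)N1C`: 16%
- compound 3, `CCCOC(=O)C1=C(C)N(C)C(=O)NC1c1ccsc1`: 11%

Compound 3 gives the smallest of the three numbers in this assay, but its gap to compound 2 lies within the scatter, so the two cannot be ordered; only against compound 1 does compound 3 sit clearly lower. Among the compounds with values here, the one step between measured compounds that differ in a single place, a number 7 percentage points lower from compound 1 to compound 2 (within the scatter), concerns the aromatic substituent on the saturated ring carbon and lies within the scatter.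

Compound 4, `CC1=C(C(=O)OCC(C)C)C(c2ccsc2)NC(=O)N1C`, differs from compound 3 only in the ester chain: methyl in place of hydrogen on a saturated chain carbon bound to two saturated chain carbons. No measured pair in this series differs in the ester chain, so nothing shown speaks to this change; the only step shown, a number 7 percentage points lower from compound 1 to compound 2 (within the scatter), is a change elsewhere and was itself within the scatter. Within the data shown here, with no step bearing on it, the expectation is that compound 4 stays near compound 3, with a number 3 percentage points higher from compound 3 to compound 4 (within the scatter) expected to fall inside the scatter. Compound 4 is therefore estimated at 14% in this assay, with a range from 3% to 27%, the breadth reflecting the absence of any comparable step.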

Compound 4, a percentage reported as inhibition, at one concentration (the size of the read-out at that concentration, not a potency): 4%
Compound 4: middle estimate off by 10 percentage points, on the high side; the measured number falls inside the stated range.
By their numbers in this assay, from the lowest: compounds 4, 3, 2 and 1 (each within the scatter of the next, the first and the last beyond it).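

In this assay, the first measured pair differing in the ester chain, propyl to isobutyl, stays within the scatter (a number 7 percentage points lower from compound 3 to compound 4 (within the scatter)), so this methyl on a saturated chain carbon bound to two saturated chain carbons does not separate the two compounds. Within the data shown here, with the isobutyl ester held constant, the aromatic group on the saturated ring carbon now gives the first steps beyond the scatter (a number 12 percentage points lower from compound 2 to compound 4 (beyond the scatter); a number 19 percentage points lower from compound 1 to compound 4 (beyond the scatter)), whereas the furan-3-yl for furan-2-yl step stayed within it. No measurement at hand offers a reason for these differences.

Going by these compounds, whether a longer chain such as butyl or pentyl, or an amide in place of the ester, would give a step beyond the scatter remains open, as does the outcome for thiophen-2-yl or phenyl on the saturated ring carbon. All numbers in this assay come from a single concentration and remain low, so they do not establish a potency order, and the series still lacks any compound with a clearly higher number than compound 1.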